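From Dimethylamino to Pyridinylmethylamino on a Weak Core

The source may report more compounds than this note shows. Statements on the series, on what has been measured and on what is new or still open speak of the compounds shown alone.

The two measured compounds were tested in a functional assay on L02 cells (Homo sapiens) for inhibition, read by Griess assay, with stated times of 1 h and 24 h; a lower number here means a stronger inhibitor, a higher number a weaker inhibitor. Compound 1, `CCCc1nn(C)c2c(NC3CC3)nc(CCc3cccnc3)nc12`, gives 564000 nM in this assay. Compound 2, `COc1cc(/C=C/c2nc(N(C)C)c3sccc3n2)cc(OC)c1OC`, is recorded only as a limit of this assay, > 1000000 nM, which is the situation described by the limit of > 1000000 nM in this assay, at which 1 of the 2 values shown sits. Compound 3, `COc1cc(/C=C/c2nc(NCc3ccncc3)c3sccc3n2)cc(OC)c1OC`, differs from compound 2 by ((pyridin-4-yl)methyl)amino in place of dimethylamino on an aromatic carbon. No measured step between two compounds is shown, so the effect of this change cannot be read from the data. Compound 3 is expected to stay weak in this assay, at about 1000000 nM, with a range from 300000 nM to 3000000 nM. The estimated step of a number no higher from compound 2 to compound 3 (the limit leaves the size open) is expected to fall within the usual scatter.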

Compound 3, half-maximal inhibitory concentration: 374000 nM
Beside the measured number, compound 3's estimate is 2.7-fold (0.43 log units) above it, within the range that was stated.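

For the compounds shown here, measured in this assay the exchange of dimethylamino for ((pyridin-4-yl)methyl)amino gives an at least 2.6-fold lower number from compound 2 to compound 3 (0.42 log units; beyond the scatter) and so shows, as the earlier compounds could not, that the number responds to the group on this aromatic carbon. Even so, compound 3 still needs 374000 nM and remains a weak inhibitor. The full size of the step cannot be read, as the value of compound 2 is only a limit: the limit of > 1000000 nM in this assay, at which 1 of the 3 values shown sits. The compounds shown leave open whether the ring nitrogen or the amine hydrogen carries this gain, and whether a benzylamino group or a longer chain between amine and pyridine would do the same.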